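Urea to amide swap in a pyrazole growth-inhibition series

The compounds below may be only part of what the source reports. "The series", "measured", "known", "first", "only" and "open" are said of these compounds alone.

Measured compounds:
- compound 1, `COc1cc(Cl)cc(-c2nn(-c3cccc(NC(=O)Nc4ccc(Cl)c(C(F)(F)F)c4)c3)cc2-c2ccncc2)c1`: -25.9%
- compound 2, `COc1cc(Cl)cc(-c2nn(-c3cccc(NC(=O)Nc4cccc(C(F)(F)F)c4)c3)cc2-c2ccncc2)c1`: -11.7%

In a functional assay on UACC-257 cells (Homo sapiens) for inhibition, read by sulforhodamine B assay, with a stated time of 48 h, tested at 10 uM (a lower number here means a stronger effect, a higher number a weaker effect of the compound at the concentration tested), compound 1 gives -25.9% and compound 2 gives -11.7%. Compound 2 stands highest of the two numbers; its nearest neighbour is compound 1, with the step of a number 14.2 percentage points higher from compound 1 to compound 2 (beyond the scatter), which replaces chloro on an aromatic carbon with hydrogen.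

Compound 3, `COc1cc(Cl)cc(-c2nn(-c3cccc(NC(=O)c4cccc(C(F)(F)F)c4)c3)cc2-c2ccncc2)c1`, is not yet measured in this assay. It differs from compound 2 by 3-(trifluoromethyl)phenyl in place of (3-(trifluoromethyl)phenyl)amino on a carbonyl carbon. Among the compounds with values here, no measured step touches the carbonyl carbon or the amide-type nitrogen, so the one recorded step, a number 14.2 percentage points higher from compound 1 to compound 2 (beyond the scatter), is at a different place and gives no direct guide. With nothing bearing on this change, the expectation is a step of no more than the scatter from compound 2, in either direction.

Compound 3 is therefore estimated at -5%, range -35% to 25%. The expected step is a number 6.7 percentage points higher from compound 2 to compound 3 (within the scatter).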

Compound 3, a percentage reported as activity, at one concentration (the size of the read-out at that concentration, not a potency): 68.7%
Compound 3: middle estimate off by 73.7 percentage points, on the low side; the measured number lies above the stated range.
By their numbers in this assay, from the lowest: compound 1; then compound 2; then compound 3.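

In this assay, within the data shown here, the carbonyl carbon proves a far more sensitive place than the chloro site: replacing (3-(trifluoromethyl)phenyl)amino with 3-(trifluoromethyl)phenyl gives a number 80.4 percentage points higher from compound 2 to compound 3 (beyond the scatter), and compound 3, at 68.7%, is the weakest of the three and the only one with a positive number. The wider step, a number 94.6 percentage points higher from compound 1 to compound 3 (beyond the scatter), also includes the loss of chloro, so it does not isolate the carbonyl-carbon change. No measurement here explains the size of either step.

Going by these compounds, it remains open whether the amino nitrogen can be replaced by an oxygen, as in a carbamate, or carry a methyl group without a similar rise. Also open, on these data alone, is whether a chloro on the 3-(trifluoromethyl)phenyl of compound 3 would lower its number.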